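From Methoxy to Isopropoxy on the Piperidinyl Group

The compounds below may be only part of what the source reports. "The series", "measured", "known", "first", "only" and "open" are said of these compounds alone.

Measured compounds:
Compound 1 `CC(C(=O)NCc1ccc(C(F)(F)F)nc1Nc1ccc(F)cc1)c1ccc(NS(C)(=O)=O)c(F)c1` gives 39.2 nM in a functional assay on CHO-K1 cells for antagonist activity at transient receptor potential cation channel subfamily V member 1 (Homo sapiens), read by FLIPR; a higher number here means a weaker inhibitor, a lower number a stronger inhibitor.
Compound 2 `COC1CCN(c2nc(C(F)(F)F)ccc2CNC(=O)C(C)c2ccc(NS(C)(=O)=O)c(F)c2)CC1` gives 2.4 nM in this assay.

Compound 2 holds the lowest number of the two, and its nearest neighbour is compound 1, reached by a 16-fold lower number from compound 1 to compound 2 (1.21 log units; beyond the scatter), a large step that came from the exchange of the (4-fluorophenyl)amino group for the 4-methoxypiperidin-1-yl group.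

Compound 3 `CC(C)OC1CCN(c2nc(C(F)(F)F)ccc2CNC(=O)C(C)c2ccc(NS(C)(=O)=O)c(F)c2)CC1` differs from compound 2 by isopropyl in place of methyl on an oxygen on a saturated carbon. Within the data shown here, no measured step touches this position: the one step on record, from compound 1 to compound 2, changed the whole group on the aromatic carbon and says nothing about the size of the alkyl on the oxygen. With nothing to point in either direction, compound 3 is expected to stay close to compound 2, with a 1.1-fold higher number from compound 2 to compound 3 (0.03 log units; within the scatter) falling within the scatter. The estimate for compound 3 in this assay is therefore 2.6 nM, between 0.8 nM and 9 nM.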

Compound 3, inhibition constant: 3 nM
Beside the measured number, compound 3's estimate is 1.2-fold (0.06 log units) below it; measured number inside the range.
By their numbers in this assay, from the lowest: compounds 2 and 3 (each within the scatter of the next); then compound 1.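

In this assay, the size of the alkyl on the oxygen makes no readable difference between methyl and isopropyl: there is a 1.3-fold higher number from compound 2 to compound 3 (0.10 log units; within the scatter), so the methoxy and isopropoxy compounds cannot be told apart. The large step away from the (4-fluorophenyl)amino group also holds with the second group, with a 13-fold lower number from compound 1 to compound 3 (1.12 log units; beyond the scatter), showing that it is not confined to 4-methoxypiperidin-1-yl. Nothing available accounts for why the two alkyl groups give such similar numbers.

On these data alone, it remains open whether a longer chain such as n-butyl, a cyclohexyl ring or a benzyl group on the same oxygen would stay as close to compound 2. As far as these compounds go, it is also open how a free hydroxyl or an amine would read in place of the whole alkoxy group.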